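A few compounds are considered here, and "the series" means these few. Any claim that something is new, unique, unknown or untested is made for them only; others in the source may bear on it.

Among the compounds with values here, in a functional assay for antagonist activity, with Cavia porcellus as the target (a higher number here means a weaker inhibitor, a lower number a stronger inhibitor), compound 2 `CN(C)CC#CCCC1(C(O)(c2ccccc2)c2ccccc2)SCCCS1` gives 1810 nM, within the scatter of compound 1 `CN(CC#CCCC1(C(O)(c2ccccc2)c2ccccc2)SCCCS1)CCCc1ccccc1` at 1630 nM, the only other number so far. Compound 3 `CCN(C)CC#CCCC1(C(O)(c2ccccc2)c2ccccc2)SCCCS1` differs from compound 2 by methyl in place of hydrogen on a saturated chain carbon bound to an amine nitrogen, with methyl in place of hydrogen on a saturated chain carbon bound to an amine nitrogen. Within the data shown here, the one measured step at that place is a 1.1-fold higher number from compound 1 to compound 2 (0.05 log units; within the scatter), which stays within the scatter. On that single step, no change beyond the scatter is expected in this assay. The expected step is a 1.1-fold lower number from compound 2 to compound 3 (0.03 log units; within the scatter). Compound 3 is estimated at 1700 nM, with an expected range of 850 nM to 3400 nM.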

Compound 3, antagonist equilibrium constant: 1230 nM
Estimate against measurement, compound 3: 1.4-fold (0.14 log units) above, within the range that was stated.
By their numbers in this assay, from the lowest: compounds 3, 1 and 2 (each within the scatter of the next).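

In this assay, methyl in place of hydrogen on a saturated chain carbon bound to an amine nitrogen gives a 1.5-fold lower number from compound 2 to compound 3 (0.17 log units; within the scatter) and so leaves the number within the scatter for dimethylamino to ethyl(methyl)amino. The listed step a 1.3-fold lower number from compound 1 to compound 3 (0.12 log units; within the scatter) also stays within the scatter, so no step among compound 1, compound 2 and compound 3 goes beyond it. No evidence at hand bears on this result.

Open, on these data alone, is whether an isopropyl group on this amine nitrogen, or an amide in place of the amine, would move the number beyond the scatter.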